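Swapping the outer pyridine ring for a chlorothiophene

The source may hold more compounds than are shown below. What is called first, only, known or untested is meant among the compounds shown, and "the series" means these compounds.

Measured compounds:
compound 1 `O=C1[C@@H](NS(=O)(=O)c2ccc(-c3ccccn3)s2)CCN1Cc1cc2[nH]cccc-2n1`: 8%
compound 2 `O=C1[C@@H](NS(=O)(=O)c2ccc(-c3ccccn3)s2)CCN1Cc1cc2c[nH]ccc-2n1`: 11%
compound 3 `O=C1[C@@H](NS(=O)(=O)c2ccc(-c3ccccn3)s2)CCN1CCNc1ccncc1`: 18%

All three were tested in an assay on isolated protein for inhibition of coagulation factor X (Oryctolagus cuniculus), tested at 1 uM; a lower number here means less inhibition, a higher number more inhibition at the concentration tested (going by the name of the read-out). Compound 1 shows the lowest of the three numbers, but its gaps to the others are small: a number 3 percentage points higher from compound 1 to compound 2 (within the scatter) and a number 10 percentage points higher from compound 1 to compound 3 (within the scatter), and also a number 7 percentage points higher from compound 2 to compound 3 (within the scatter). Each of these steps changes only the group on the saturated chain carbon bound to the amide-type nitrogen in a ring, and none of them moves the read-out beyond the usual scatter.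

Compound 4 `O=C1[C@@H](NS(=O)(=O)c2ccc(-c3ccc(Cl)s3)s2)CCN1Cc1cc2[nH]cccc-2n1` is built from compound 1 by a change elsewhere: 5-chlorothiophen-2-yl in place of pyridin-2-yl on an aromatic carbon. Among the compounds with values here, no measured step touches this position, so the three measured steps give no guide to its size or direction; they only show that the shared core of compound 1 sits at a low level of inhibition in this assay. Without a precedent, the expectation for compound 4 is a modest number with a wide range, and the expected step of a number 12 percentage points higher from compound 1 to compound 4 (beyond the scatter) is uncertain in direction. The estimate for compound 4 in this assay is 20%, between 3% and 55%.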

Compound 4, a percentage reported as inhibition, at one concentration (the size of the read-out at that concentration, not a potency): 42%
Compound 4: middle estimate off by 22 percentage points, on the low side; the measured number falls inside the stated range.
By their numbers in this assay, from the lowest: compounds 1, 2 and 3 (each within the scatter of the next); then compound 4.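

In this assay the position on an aromatic carbon of a five-membered aromatic ring with 1 sulfur proves far more responsive than the one varied so far: 5-chlorothiophen-2-yl in place of pyridin-2-yl gives a number 34 percentage points higher from compound 1 to compound 4 (beyond the scatter) while every step among compound 1, compound 2 and compound 3 stayed within the scatter. The two groups match in heavy atoms, hydrogen-bond donors and hydrogen-bond acceptors as counted, and neither carries a net charge, so the rise does not follow those counts; what differs is a six-membered ring with nitrogen against a five-membered ring with sulfur that also bears a chlorine. Nothing available here accounts for the rise.

As far as these compounds go, it remains open whether the chlorine or the thiophene ring matters more, a question that plain thiophen-2-yl, 5-methylthiophen-2-yl or 5-chloropyridin-2-yl at this position would help to settle. From the compounds shown here alone, it is also open whether the same swap would raise the number for compound 2 and compound 3, and how the read-out at a single concentration relates to potency.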